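This account rests on a few compounds, and the source may have more. Where it says the series, first, only, none or still open, it means among the compounds named here.

Compound 1 `c1ccc(-c2cc(CNc3nncc(-c4cccc5ccccc45)n3)n[nH]2)cc1` in an ADME assay on CEM174 cells (Homo sapiens) for cytotoxicity (a lower number here means that less compound is tolerated, a higher number that more compound is tolerated), gives > 10000 nM, which is a limit of the assay.
Compound 2 `Cc1cccc(-c2cnnc(NCc3cc(-c4ccccc4)[nH]n3)n2)c1` in this assay gives > 10000 nM, also a limit.
Compound 3 `Cc1ccccc1-c1ccnc(NCc2cc(-c3ccccc3)[nH]n2)n1` in this assay gives > 10000 nM, again a limit.

Compound 3 therefore stands at the limit of > 10000 nM in this assay, at which 3 of the 3 values shown sit, with no number of its own to order it against compound 1 or compound 2. The change to compound 4 `Cc1cc(C#N)ccc1-c1ccnc(NCc2cc(-c3ccccc3)[nH]n2)n1` is cyano in place of hydrogen on an aromatic carbon. For the measured compounds named here, no step between measured compounds is available for this assay, so the expectation rests on the fact that every value shown sits at the limit. In this assay the step that the limit leaves unreadable from compound 3 to compound 4 is expected to be none beyond the scatter, because the limit of > 10000 nM in this assay, at which 3 of the 3 values shown sit, holds all three measured compounds. Compound 4 is estimated at 15000 nM, in the range 5000 nM to 50000 nM.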

Compound 4, half-maximal cytotoxic concentration: > 10000 nM
Compound 4 was reported as a limit (the forecaster's own chance of this, stated with the estimate: 80%); the middle value does not contradict the limit.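

No step can be read between compound 3 and compound 4 in this assay: the limit of > 10000 nM in this assay, at which 4 of the 4 values shown sit. The compounds shown leave open whether cyano in place of hydrogen changes the tolerated concentration at all, and how any of these compounds compare with one another.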